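The source may report more compounds than this note shows. Statements on the series, on what has been measured and on what is new or still open speak of the compounds shown alone.

Series notes. Compound 1 `CC/C=C\C/C=C\C/C=C\CCCCCCCc1cc(OC(C)=O)cc(OC(C)=O)c1` and compound 2 `CC/C=C\C[C@@H](O)CC/C=C\CCCCCCCc1cc(O)cc(O)c1` have been run in an ADME assay on Vero cells (Homo sapiens) for cytotoxicity against Vero (Chlorocebus sabaeus), read by MTT assay; on this read-out lower numbers stand for stronger inhibition and higher numbers for weaker inhibition. In this assay compound 1 gives 138000 nM, the highest number of the two. In this assay, going by the values given here, compound 2 gives 30000 nM, a lower number, and the gap between the two values lies beyond the usual scatter; no single-point step links these two compounds, so only the two values themselves can be read.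

Compound 3 `CC/C=C\C[C@H](CC/C=C\CCCCCCCc1cc(OC(C)=O)cc(OC(C)=O)c1)OC(C)=O` has not yet been measured in this assay. It differs from compound 1 in one place: a group of 11 heavy atoms (9 carbon, 2 oxygen; no ring) in place of a group of 7 heavy atoms (7 carbon; no ring), on a saturated chain carbon bound to a double-bonded chain carbon. The diacetylated core of compound 1 is kept; the change sits on the chain alone.

Among the compounds with values here, no measured pair shows what this change does. The expectation is a small step, a 1.4-fold lower number from compound 1 to compound 3 (0.14 log units; within the scatter), toward a somewhat lower number, not clearly beyond the scatter. For compound 3 the value in this assay is estimated at 100000 nM, within a range from 40000 nM to 250000 nM.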

Compound 3, half-maximal inhibitory concentration: 82000 nM
The estimate for compound 3 lay 1.2-fold (0.09 log units) above the measured number; the range from low to high includes it.
By their numbers in this assay, from the lowest: compound 2; then compounds 3 and 1 (each within the scatter of the next).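

In this assay, placing the group of 11 heavy atoms, with 2 hydrogen-bond acceptors and 1 defined stereocentre, in place of hepta-1,4-dien-1-yl on a saturated chain carbon bound to a double-bonded chain carbon gives a 1.7-fold lower number from compound 1 to compound 3 (0.23 log units; within the scatter). Going by these compounds alone, this is the first single-place step, and it shows that this change on the chain, with the core of compound 1 kept, stays within the scatter. No supporting data bear on this step.

Going by these compounds, whether an amine or a carboxylic acid at this place would give a step beyond the scatter remains open, as does the reading for the opposite configuration at the stereocentre. Within the data shown here, compound 2 is linked to the other compounds by no single-place step, so its steps cannot be read.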